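Swapping Both Substituents on the Amide Nitrogen of Compound 1

The compounds below may be only part of what the source reports. "The series", "measured", "known", "first", "only" and "open" are said of these compounds alone.

Measured compounds:
Compound 1 `C/C(=C\c1ccc(C(=O)Oc2ccc(C(=N)N)cc2)cc1)C(=O)N(CC(=O)O)C1CCCC1` gives 0.7 h in an in vitro ADME assay on the whole organism (small intestine) for pharmacokinetics, with Rattus norvegicus as the target; a higher number here means that the compound lasts longer, a lower number that the compound disappears faster
Compound 2 `C/C(=C\c1ccc(C(=O)Oc2ccc(C(=N)N)cc2)cc1)C(=O)N(CC(=O)O)Cc1ccccc1` gives 0.833 h in this assay

Going by the values given here, compound 1 has the lowest of the two numbers known so far, and its nearest neighbour is compound 2, separated by a 1.2-fold higher number from compound 1 to compound 2 (0.08 log units; within the scatter). That single step, benzyl in place of cyclopentyl on an amide-type nitrogen, is within the scatter, so the two compounds cannot be told apart on this evidence.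

The unmeasured compound 3 `C=CCN(CCC(=O)OCC)C(=O)/C(C)=C/c1ccc(C(=O)Oc2ccc(C(=N)N)cc2)cc1` differs from compound 1 as follows: allyl(2-(ethoxycarbonyl)ethyl)amino in place of (carboxymethyl)(cyclopentyl)amino on a carbonyl carbon. Among the compounds with values here, this change is larger than the one between compound 1 and compound 2, since it replaces both groups on the nitrogen at once and exchanges a free acid for an ethyl ester. Within the data shown here, the only step available, a 1.2-fold higher number from compound 1 to compound 2 (0.08 log units; within the scatter), bears on the nitrogen substituent alone and was within the scatter; no measured pair speaks to the acid-to-ester exchange. With nothing pointing in either direction, the step from compound 1 to compound 3 is expected to be a 1.2-fold lower number from compound 1 to compound 3 (0.07 log units; within the scatter), but with a wide range. Compound 3 is therefore estimated at 0.6 h, between 0.25 h and 1.5 h.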

Compound 3, half-life: 1 h
For compound 3 the middle estimate is 1.7-fold (0.22 log units) below the measured one; the range from low to high includes it.
By their numbers in this assay, from the lowest: compounds 1, 2 and 3 (each within the scatter of the next).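

Replacing the entire (carboxymethyl)(cyclopentyl)amino group on the carbonyl carbon with allyl(2-(ethoxycarbonyl)ethyl)amino is a far larger change than the benzyl swap, yet in this assay it gives a 1.4-fold higher number from compound 1 to compound 3 (0.15 log units; within the scatter). The free acid, with its hydrogen-bond donor, gives way to an ethyl ester, and the five-membered ring gives way to an open allyl chain, so this position tolerates a very different group without moving the half-life outside the scatter of repeated measurements. Nothing at hand explains this result or links it to any one part of the change.

Three changes arrive together in this single step: the ester for the acid, the loss of the cyclopentyl ring and the arrival of allyl, so the compounds shown leave the contribution of each one open, and any of them could be offsetting another. Also open, going by these compounds, is how this assay would respond to a different kind of group at the end of the chain, such as an amine or a hydroxyl, or to a longer chain.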